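This account rests on a few compounds, and the source may have more. Where it says the series, first, only, none or still open, it means among the compounds named here.

Measured in a functional assay on HCT-116 cells (Homo sapiens) for cytotoxicity, read by MTT assay, with a stated time of 72 h; on this read-out lower numbers stand for stronger inhibition and higher numbers for weaker inhibition:
- compound 1 `Cc1ccc(S(=O)(=O)c2nc3ccccc3nc2Nc2cccc(N)c2)cc1` gives 2390 nM
- compound 2 `COc1ccc(Nc2nc3ccccc3nc2S(=O)(=O)c2ccc(F)cc2)cc1` gives 3010 nM
- compound 3 `COc1cc(Nc2nc3ccccc3nc2S(=O)(=O)c2ccc(F)cc2)cc(OC)c1` gives 3930 nM

Compound 3, at 3930 nM, lies within the scatter of both other compounds, so the three values carry no rank. Among the compounds with values here, the only measured single-place step, a 1.3-fold higher number from compound 2 to compound 3 (0.12 log units; within the scatter), exchanges 4-methoxyphenyl for 3,5-dimethoxyphenyl on a nitrogen on an aromatic ring and stays within the scatter.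

Next in the series is compound 4 `Nc1cccc(Nc2nc3ccccc3nc2S(=O)(=O)c2ccc(F)cc2)c1`, not yet measured. The change is 3-aminophenyl in place of 3,5-dimethoxyphenyl on a nitrogen on an aromatic ring, putting 3-aminophenyl in place of 3,5-dimethoxyphenyl on a nitrogen on an aromatic ring. Within the data shown here, no measured step isolates this exchange. The closest evidence is compound 1, which also carries 3-aminophenyl and gives 2390 nM, within the scatter of compound 3.

No change beyond the scatter is therefore expected in this assay. The expected step is a 1.4-fold lower number from compound 3 to compound 4 (0.15 log units; within the scatter), which stays within the scatter. For compound 4 the estimated value is 2800 nM. The expected range runs from 1300 nM to 6000 nM.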

Compound 4, half-maximal inhibitory concentration: 6790 nM
For compound 4 the middle estimate is 2.4-fold (0.38 log units) below the measured one, and the stated range ends below it.
By their numbers in this assay, from the lowest: compounds 1, 2, 3 and 4 (each within the scatter of the next, the first and the last beyond it).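

In this assay, the exchange at the nitrogen on an aromatic ring gives a 1.7-fold higher number from compound 3 to compound 4 (0.24 log units; within the scatter), so 3-aminophenyl and 3,5-dimethoxyphenyl remain unseparated at this position. Set against 4-methoxyphenyl, 3-aminophenyl gives a 2.3-fold higher number from compound 2 to compound 4 (0.35 log units; beyond the scatter), a modest step and the only one at this position so far to pass the scatter. With 3-aminophenyl held constant, fluoro in place of methyl on an aromatic carbon gives a 2.8-fold higher number from compound 1 to compound 4 (0.45 log units; beyond the scatter), which shows that the number also responds to a change outside this position, again modestly.

On these data alone, whether a cyclohexyl group or a 3-carboxyphenyl group on the same nitrogen, or chloro in place of fluoro on the aromatic carbon, would move the number further stays open. Nothing available gives a reason for these steps.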